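Pyridin-2-yl in place of methyl: outlook for compound 3

The compounds below may be only part of what the source reports. "The series", "measured", "known", "first", "only" and "open" are said of these compounds alone.

For the measured compounds named here, in a functional assay on MCF7 cells (Homo sapiens) for antiproliferative activity, read by sulforhodamine B assay, with a stated time of 48 h (on this read-out higher numbers stand for weaker inhibition and lower numbers for stronger inhibition), compound 1 (`COc1ccc(C[C@@H](O)/C=C/C=C/C(=O)N2CCN(C)CC2)cc1OC`) gives 17100 nM and compound 2 (`COc1ccc(C[C@@H](O)/C=C/C=C/C(=O)NCc2ccccc2)cc1OC`) gives 33600 nM, the only two numbers so far, within the scatter of each other. Compound 3 (`COc1ccc(C[C@@H](O)/C=C/C=C/C(=O)N2CCN(c3ccccn3)CC2)cc1OC`) carries pyridin-2-yl in place of methyl on an amine nitrogen in a ring. Going by the values given here, the sole measured step (a 2.0-fold higher number from compound 1 to compound 2 (0.29 log units; within the scatter)) sits on a carbonyl carbon, not at this place, so it gives weak guidance and no direction. The expected step in this assay stays within the scatter, and the estimate is a 1.1-fold lower number from compound 1 to compound 3 (0.06 log units; within the scatter) as the likely outcome. For compound 3 the expected value is 15000 nM, with an estimated range of 6000 nM to 40000 nM.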

Compound 3, half-maximal inhibitory concentration: 23600 nM
Beside the measured number, compound 3's estimate is 1.6-fold (0.20 log units) below it; the measured number falls inside the stated range.
By their numbers in this assay, from the lowest: compounds 1, 3 and 2 (each within the scatter of the next).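

In this assay, for the compounds shown here, the first step at this place, on an amine nitrogen in a ring, stays within the scatter (a 1.4-fold higher number from compound 1 to compound 3 (0.14 log units; within the scatter)). Compound 3 shows that a six-membered aromatic ring with 1 hetero atom can replace methyl here without a readable difference from compound 1. No measured evidence on the cause of this result is available.

Open, as far as these compounds go, is whether a carboxylic acid or a primary amine on a longer chain at this nitrogen would give a step beyond the scatter. Also open, from the compounds shown here alone, is how substituted pyridin-2-yl groups would read here.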